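Working notes: distribution coefficient across three analogues

The source may hold more compounds than are shown below. What is called first, only, known or untested is meant among the compounds shown, and "the series" means these compounds.

Measured so far:
compound 1 `Cc1cc(C(=O)NCc2ccncc2)nn1Cc1cc(Cl)ccc1OCc1ccccc1` — > 3.7
compound 2 `Cc1cc(NC(=O)C2CCCC2)nn1Cc1cc(Cl)ccc1OCC(C)C` — > 3.7

In a physicochemical assay for lipophilicity, at pH 7.4 (on this read-out lower numbers stand for lower lipophilicity and higher numbers for higher lipophilicity), compound 1 gives > 3.7, which is a limit of the assay and not a number. Compound 2 gives > 3.7 in this assay, also a limit. Among the measured compounds shown here, both values stand at the limit of > 3.7 in this assay, at which 2 of the 2 values shown sit, so compound 1 cannot be ordered against compound 2, and no measured pair differs in a single place, so no measured step exists.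

Compound 3 `Cc1cc(NC(=O)OC(C)(C)C)nn1Cc1cc(Cl)ccc1OCc1ccccc1` is still to be measured. It differs from compound 1 by (tert-butoxycarbonyl)amino in place of ((pyridin-4-yl)methyl)carbamoyl on an aromatic carbon. For the measured compounds named here, with no measured step to draw on, the step from compound 1 to compound 3 is expected to be a step that the limit leaves unreadable from compound 1 to compound 3, which would leave the result at or past the limit of this assay. For compound 3 the estimate is 4.4, with a range from 3.8 to 5, and a further limit read-out is the most likely outcome.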

Compound 3, distribution coefficient: > 3.7
Compound 3: only a limit was reported; the forecaster's own chance of this, stated with the estimate: 85%; the middle value does not contradict the limit.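

In this assay compound 3 gives > 3.7, which is a limit and not a number, so the step from compound 1 to compound 3 cannot be read: the limit of > 3.7 in this assay, at which 3 of the 3 values shown sit.

The compounds shown leave open how compound 1, compound 2 and compound 3 order against one another in this assay.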